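N-benzyl analogue in the cytotoxicity series

The source may hold more compounds than are shown below. What is called first, only, known or untested is meant among the compounds shown, and "the series" means these compounds.

Working notes on the thiosemicarbazone series. Compound 1 `O=C1Nc2ccccc2/C1=N/NC(=S)Nc1ccc(F)cc1` carries a fluorine on the outer phenyl ring and an unsubstituted ring nitrogen in the core. In an ADME assay on RD cells (Homo sapiens) for cytotoxicity (on this read-out higher numbers stand for lower toxicity in this test and lower numbers for higher toxicity in this test), compound 1 gives only a limit, > 25000 nM. Compound 2 `CN1C(=O)/C(=N\NC(=S)Nc2ccccc2)c2ccccc21` has no fluorine and a methyl on the ring nitrogen. In this assay compound 2 also gives only a limit, > 25000 nM. Both values therefore sit at the limit of > 25000 nM in this assay, at which 2 of the 2 values shown sit, so compound 2 stands at the limit itself, and no ordering of the two compounds can be read from the numbers shown.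

Compound 3 `O=C1/C(=N\NC(=S)Nc2ccccc2)c2ccccc2N1Cc1ccccc1` is not yet measured. It differs from compound 2 by phenyl in place of hydrogen on a saturated chain carbon bound to an amide-type nitrogen in a ring; cut one bond further out, the change reads methyl to benzyl. Going by the values given here, no step between measured compounds is available, so the size of the step can only be expected: a modest move toward higher toxicity is anticipated, with a fair chance that the result again stays within the scatter of the limit, giving an expected step of an at least 1.2-fold lower number from compound 2 to compound 3 (0.09 log units; that floor lies within the scatter). On that basis compound 3 is estimated at 20000 nM, within the range 5000 nM to 60000 nM.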

Compound 3, half-maximal cytotoxic concentration: > 25000 nM
Compound 3: a limit, no number; the forecaster's own chance of this, stated with the estimate: 55%; at least 1.2-fold (0.09 log units) between middle value and limit.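

In this assay compound 3 gives > 25000 nM, a limit and not a number. Compound 2 also gives only a limit, so no step can be read between compound 2 and compound 3: the limit of > 25000 nM in this assay, at which 3 of the 3 values shown sit.

The compounds shown leave open whether methyl to benzyl shifts the read-out at all in this assay.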